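Bulkier amine substituents on a shared core and cell toxicity

The source may report more compounds than this note shows. Statements on the series, on what has been measured and on what is new or still open speak of the compounds shown alone.

Measured compounds:
compound 1, `CCCCOc1ccc(-c2nc3ncccn3c2NCC2CCCCC2)cc1`, 35000 nM
compound 2, `CCCCOc1ccc(-c2nc3ncccn3c2NCCC)cc1`, > 100000 nM
compound 3, `CCCCOc1ccc(-c2nc3ncccn3c2NC(C)C)cc1`, 68000 nM

Three compounds share one core and differ only in the group on the nitrogen on the aromatic ring. In a toxicity assay on A549 cells (Homo sapiens) for cytotoxicity, read by luminescence and CellTiter-Glo, with a stated time of 48 h (on this read-out lower numbers stand for higher toxicity in this test and higher numbers for lower toxicity in this test), compound 1 gives 35000 nM. Compound 2 reaches only a limit of the assay, > 100000 nM. Compound 3 gives 68000 nM, and its step from compound 1, a 1.9-fold higher number from compound 1 to compound 3 (0.29 log units; within the scatter), lies within the scatter, so the two numbers cannot be told apart. The step of an at least 2.8-fold higher number from compound 1 to compound 2 (0.45 log units; beyond the scatter) is beyond the scatter, while an at least 1.4-fold lower number from compound 2 to compound 3 (0.16 log units; that floor lies within the scatter) is not.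

Compound 4, `CCCCOc1ccc(-c2nc3ncccn3c2NC(C)(C)CC(C)(C)C)cc1`, is not yet measured. It differs from compound 3 by neopentyl in place of hydrogen on a saturated chain carbon bound to a nitrogen on an aromatic ring and two saturated chain carbons. Larger groups here have not moved the numbers in one direction: cyclohexylmethyl in compound 1 sits within the scatter of isopropyl in compound 3, and propyl in compound 2 gave a limit. For compound 4 the expected step is therefore a 1.2-fold lower number from compound 3 to compound 4 (0.09 log units; within the scatter), not beyond the scatter. Compound 4 is estimated at 55000 nM, between 18000 nM and 150000 nM.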

Compound 4, half-maximal cytotoxic concentration: 29000 nM
Compound 4: the middle estimate sits 1.9-fold (0.28 log units) above what was measured, within the range that was stated.
By their numbers in this assay, from the lowest: compounds 4, 1 and 3 (each within the scatter of the next, the first and the last beyond it). At a limit, above all of these: compound 2.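

Neopentyl added to compound 3 gives a change beyond the scatter, a 2.3-fold lower number from compound 3 to compound 4 (0.37 log units; beyond the scatter), so in this assay a larger branched group on this nitrogen can lower the number. Yet a 1.2-fold lower number from compound 1 to compound 4 (0.08 log units; within the scatter) lies within the scatter, so 1,1,3,3-tetramethylbutyl and cyclohexylmethyl cannot be told apart here, although only the second carries a ring. Against propyl, an at least 3.4-fold lower number from compound 2 to compound 4 (0.53 log units; beyond the scatter) gives only a floor, since compound 2 stands at a limit of the assay: the limit of > 100000 nM in this assay, at which 1 of the 4 values shown sits.

The compounds shown leave open whether size alone sets these numbers, and compound 2 offers no exact number to test that idea. Also open, going by these compounds, is how a chain carrying an amine or a carboxylic acid on this nitrogen would read in place of these plain carbon groups.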